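The compounds below may be only part of what the source reports. "The series", "measured", "known", "first", "only" and "open" are said of these compounds alone.

Measured so far:
- Compound 1 `CCS(=O)(=O)Nc1cccc2c1CCCC2c1c[nH]cn1` gives, in an assay on isolated protein for agonist activity at Alpha-1A adrenergic receptor (Oryctolagus cuniculus) (a lower number here means that less compound is needed, a higher number that more compound is needed for the effect), 631 nM.
- Compound 2 `CC(C)S(=O)(=O)Nc1cccc2c1CCCC2c1c[nH]cn1` gives, in this assay, 6760 nM.

Among the measured compounds shown here, compound 2 stands at the higher of these two numbers, with compound 1 as its only neighbour. The next compound, compound 3 `O=S(=O)(Nc1cccc2c1CCCC2c1c[nH]cn1)C1CC1`, differs from compound 2 by cyclopropyl in place of isopropyl on a sulfonyl sulfur. For the measured compounds named here, the one step that touches this same sulfonyl substituent is an 11-fold higher number from compound 1 to compound 2 (1.03 log units; beyond the scatter). A cyclopropyl is neither the ethyl of compound 1 nor the isopropyl of compound 2, so compound 3 is expected to land between them, and the step of a 3.4-fold lower number from compound 2 to compound 3 (0.53 log units; beyond the scatter) is estimated as a moderate drop. For compound 3 the expected value is 2000 nM, within 600 nM to 7000 nM.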

Compound 3, half-maximal effective concentration: 5620 nM
Beside the measured number, compound 3's estimate is 2.8-fold (0.45 log units) below it, and the stated range covers the measured number.
By their numbers in this assay, from the lowest: compound 1; then compounds 3 and 2 (each within the scatter of the next).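

Isopropyl and cyclopropyl on the sulfonyl sulfur read alike here, with a 1.2-fold lower number from compound 2 to compound 3 (0.08 log units; within the scatter), even though only cyclopropyl carries a ring. Cyclopropyl stands well apart from ethyl, with an 8.9-fold higher number from compound 1 to compound 3 (0.95 log units; beyond the scatter), so closing the ring does not bring back the number of compound 1. Nothing available explains this result.

Going by these compounds, whether methyl, a longer chain such as propyl, or a phenyl group on the sulfonyl sulfur would fall with ethyl or with the other two remains open. So does whether any group there gives a lower number than ethyl.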